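A few compounds are considered here, and "the series" means these few. Any claim that something is new, unique, unknown or untested is made for them only; others in the source may bear on it.

Measured so far in a functional assay on QGY7701 cells (Homo sapiens) for cytotoxicity, read by MTT assay, with a stated time of 48 h; on this read-out lower numbers stand for stronger inhibition and higher numbers for weaker inhibition:
compound 1 `O=c1ccoc2cc(OCc3cn(Cc4ccc([N+](=O)[O-])cc4)nn3)ccc12`, > 100000 nM
compound 2 `O=c1ccoc2cc(OCc3cn(Cc4ccccc4Br)nn3)ccc12`, > 100000 nM
compound 3 `O=c1ccoc2cc(OCc3cn(Cc4ccc(Cl)cc4)nn3)ccc12`, 41700 nM

In this assay compound 1 gives only a limit, > 100000 nM. Compound 2 likewise gives only a limit, > 100000 nM. The step that the two limits leave unreadable from compound 1 to compound 2 is therefore not readable. Compound 3 gives a number, 41700 nM, so that an at least 2.3-fold lower number from compound 1 to compound 3 (0.37 log units; beyond the scatter) and an at least 2.3-fold lower number from compound 2 to compound 3 (0.37 log units; beyond the scatter) are both at least modest.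

Compound 4 `COc1ccc(Cn2cc(COc3ccc4c(=O)ccoc4c3)nn2)cc1` differs from compound 1 by methoxy in place of nitro on an aromatic carbon. Going by the values given here, the only measured step that bears on this is an at least 2.3-fold lower number from compound 1 to compound 3 (0.37 log units; beyond the scatter), which shows that exchanging nitro for chloro on that carbon brings the number below (the limit of > 100000 nM in this assay, at which 2 of the 3 values shown sit). Whether methoxy does the same is not shown by any measured pair. The step expected is an at least 1.6-fold lower number from compound 1 to compound 4 (0.22 log units; that floor lies within the scatter), with a real chance that only a limit is reported again. Compound 4 is estimated at 60000 nM, range 20000 nM to 200000 nM.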

Compound 4, half-maximal inhibitory concentration: 56600 nM
For compound 4 the middle estimate is 1.1-fold (0.03 log units) above the measured one; low and high end bracket the measured number.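

In this assay, methoxy on this aromatic carbon gives a number close to that of chloro, with a 1.4-fold higher number from compound 3 to compound 4 (0.13 log units; within the scatter), so the two groups cannot be told apart here. The exchange for nitro reads an at least 1.7-fold lower number from compound 1 to compound 4 (0.24 log units; that floor lies within the scatter), and the exchange of the whole 2-bromophenyl reads an at least 1.7-fold lower number from compound 2 to compound 4 (0.24 log units; that floor lies within the scatter), so neither floor alone establishes a real gain. Both reference compounds remain unquantified: the limit of > 100000 nM in this assay, at which 2 of the 4 values shown sit.

On these data alone, what an amine or a carboxylic acid on this carbon would give stays open. As far as these compounds go, the true size of the step from nitro also stays open, as only a number for compound 1 could fix it.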